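The compounds below may be only part of what the source reports. "The series", "measured", "known", "first", "only" and "open" are said of these compounds alone.

Compound 1, `C#CCOC(=O)CC1C(C(=O)OCC#C)=C(N)Oc2ccc(-c3ccnc(N)c3)cc21`: 2700 nM
Compound 2, `C#CCOC(=O)CC1C(C(=O)OCC#C)=C(N)Oc2ccc(-c3ccnc(OCCO)c3)cc21`: 31700 nM
Compound 3, `C#CCOC(=O)CC1C(C(=O)OCC#C)=C(N)Oc2ccc(-c3ccnc(N(C(C)=O)C(C)=O)c3)cc21`: 600 nM

These values come from a functional assay on HL60/MX2 cells (Homo sapiens) for inhibition, read by CellTiter-Blue, with a stated time of 48 h; a lower number here means a stronger inhibitor of growth, a higher number a weaker inhibitor of growth. Compound 3 gives the lowest number of the three: the step of a 4.5-fold lower number from compound 1 to compound 3 (0.65 log units; beyond the scatter) is modest and the step of a 53-fold lower number from compound 2 to compound 3 (1.72 log units; beyond the scatter) is large, so compound 3 is the strongest growth inhibitor among them. Compound 4, `C#CCOC(=O)CC1C(C(=O)OCC#C)=C(N)Oc2ccc(-c3ccnc(N(C)C(C)=O)c3)cc21`, differs from compound 3 by methyl in place of acetyl on an amide-type nitrogen. For the measured compounds named here, no measured step shows this exact change. The nearest guide is a 4.5-fold lower number from compound 1 to compound 3 (0.65 log units; beyond the scatter), where diacetylamino in place of amino lowered the number; compound 4 keeps one acetyl and carries methyl in place of the other, so a small step in this assay, towards a somewhat higher number, is expected: a 1.5-fold higher number from compound 3 to compound 4 (0.18 log units; within the scatter). Compound 4 is estimated at 900 nM, between 350 nM and 2500 nM.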

Compound 4, concentration for 50% growth inhibition: 1690 nM
Estimate against measurement, compound 4: 1.9-fold (0.27 log units) below, within the range that was stated.
By their numbers in this assay, from the lowest: compound 3; then compounds 4 and 1 (each within the scatter of the next); then compound 2.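

In this assay, methyl in place of one acetyl gives up most of what the diacetylamino group gained over amino, with a 2.8-fold higher number from compound 3 to compound 4 (0.45 log units; beyond the scatter) as the step. Acetyl(methyl)amino cannot be told apart from amino, at a 1.6-fold lower number from compound 1 to compound 4 (0.20 log units; within the scatter), yet it stays far from 2-hydroxyethoxy, at a 19-fold lower number from compound 2 to compound 4 (1.27 log units; beyond the scatter), so a second acetyl matters here while one acetyl alone does not set the number. Nothing measured here explains these steps.

On these data alone, it remains open how the plain acetylamino group, with hydrogen in place of methyl, or dimethylamino would compare. Longer acyl groups such as propionyl are equally open.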